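Halogen position on the anilino ring: compound 2 to compound 4

The compounds below may be only part of what the source reports. "The series", "measured", "known", "first", "only" and "open" are said of these compounds alone.

The series shares one core; the compounds differ in the aryl on the amino nitrogen and in the saturated amine on the bicyclic core. In a functional assay on MV4-11 cells (Homo sapiens) for inhibition, with a stated time of 120 h, tested at 10 uM (on this read-out higher numbers stand for more inhibition at the one concentration tested (going by the name of the read-out) and lower numbers for less inhibition), compound 1 `Cc1n[nH]c2ccc(-c3nc4cnc(N5CCN(C)CC5)cn4c3Nc3ccccc3F)cc12` gives 0%, compound 2 `Cc1n[nH]c2ccc(-c3nc4cnc(N5CCN(C)CC5)cn4c3Nc3ccccc3Cl)cc12` gives 58.1% and compound 3 `Cc1n[nH]c2ccc(-c3nc4cnc(N5CCC(C)CC5)cn4c3Nc3ccc(Cl)cc3)cc12` gives 28%. Compound 2 stands highest of the three: compound 3 lies nearest, and compound 1 furthest, both beyond the scatter. Going by the values given here, the one single-point step measured so far is a number 58.1 percentage points higher from compound 1 to compound 2 (beyond the scatter), a large rise. Compound 4 `Cc1n[nH]c2ccc(-c3nc4cnc(N5CCN(C)CC5)cn4c3Nc3ccc(Br)cc3)cc12` differs from compound 2 by 4-bromophenyl in place of 2-chlorophenyl on a nitrogen on an aromatic ring. Among the compounds with values here, no measured step bears directly on this change: compound 3 also carries a halogen in the 4-position of the anilino ring but differs from compound 2 in the amine as well, so its lower value can only be noted, not attributed. Within the data shown here, with no direct precedent, and compound 3 sitting below compound 2, a moderate fall in this assay is expected for compound 4, as a step of a number 23.1 percentage points lower from compound 2 to compound 4 (beyond the scatter). The estimate for compound 4 is 35%, with a range from 5% to 65%.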

Compound 4, a percentage reported as inhibition, at one concentration (the size of the read-out at that concentration, not a potency): 83%
Estimate against measurement, compound 4: 48 percentage points below, outside the stated range (above it).
By their numbers in this assay, from the lowest: compound 1; then compound 3; then compound 2; then compound 4.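

In this assay, the read-out does not top out at 2-chlorophenyl on this nitrogen: 4-bromophenyl in its place gives a number 24.9 percentage points higher from compound 2 to compound 4 (beyond the scatter). With the saturated amine held constant, the same group in place of 2-fluorophenyl gives a number 83 percentage points higher from compound 1 to compound 4 (beyond the scatter), so the choice of aryl alone spans a wide range in this small set. The halogen and its place on the ring change together in these steps, so neither can be credited alone, and no supporting data explain the rise.

Still open, on these data alone, is whether the high read-out depends on a halogen at all, or whether a nitrile, a methoxy group or an amine on the phenyl would serve as well. Also open, as far as these compounds go, is how 4-bromophenyl behaves with a different saturated amine on the shared core.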